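Amine-side substituent survey on the shared core

The compounds below may be only part of what the source reports. "The series", "measured", "known", "first", "only" and "open" are said of these compounds alone.

The series keeps the core of compound 1 `COc1cc(N)c(Cl)cc1NC(=O)C1CCN(Cc2cccc(C#N)c2)CC1` and varies the group on a saturated chain carbon bound to an amine nitrogen in a ring. In a functional assay on the whole organism for antagonist activity, with Mus musculus as the target (on this read-out lower numbers stand for an effect already at smaller amounts and higher numbers for an effect only at larger amounts of compound), compound 1 gives only a limit, > 4 mg/kg. Compound 2 `COc1cc(N)c(Cl)cc1NC(=O)C1CCN(CC2CCC2)CC1` carries cyclobutyl in place of 3-cyanophenyl and in this assay compound 2 also stays at a limit, > 10 mg/kg. Compound 3 `CCN1CCC(C(=O)Nc2cc(Cl)c(N)cc2OC)CC1` carries methyl at that place, and in this assay compound 3 likewise reaches only a limit, > 10 mg/kg. Compound 1 thus stands at a limit among three limits, with the limit of > 4 mg/kg in this assay, at which 1 of the 3 values shown sits, for compound 1 and the limit of > 10 mg/kg in this assay, at which 2 of the 3 values shown sit, for the other two. The steps a step that the two limits leave unreadable from compound 1 to compound 2, a step that the two limits leave unreadable from compound 1 to compound 3 and a step that the two limits leave unreadable from compound 2 to compound 3 consequently carry no readable size.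

Compound 4 `COc1cc(N)c(Cl)cc1NC(=O)C1CCN(CC2CCCCC2)CC1` differs from compound 1 by cyclohexyl in place of 3-cyanophenyl on a saturated chain carbon bound to an amine nitrogen in a ring. The nearest measured step, a step that the two limits leave unreadable from compound 1 to compound 2, gives neither size nor direction, so nothing in the measured set points to a step beyond the scatter in either direction; the likeliest outcome is another limit. The expected step is a step that the limit leaves unreadable from compound 1 to compound 4. For compound 4 the estimate in this assay is 12 mg/kg, with a range from 4 mg/kg to 40 mg/kg.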

Compound 4, dose for half-maximal effect: 2.9 mg/kg
Compound 4: middle estimate off by 4.1-fold (0.62 log units), on the high side; the whole stated range lies above it.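

Among the compounds shown, only compound 4 gives a number rather than a limit in this assay, so a readable effect at this place on a saturated chain carbon bound to an amine nitrogen in a ring now exists, and it comes with cyclohexyl. Cyclohexyl in place of cyclobutyl gives an at least 3.4-fold lower number from compound 2 to compound 4 (0.53 log units; beyond the scatter), and cyclohexyl in place of methyl gives an at least 3.4-fold lower number from compound 3 to compound 4 (0.53 log units; beyond the scatter); both steps are beyond the scatter, but each is only a floor because the compound it starts from sits at a limit: the limit of > 10 mg/kg in this assay, at which 2 of the 4 values shown sit. Cyclohexyl in place of 3-cyanophenyl gives an at least 1.3-fold lower number from compound 1 to compound 4 (0.13 log units; that floor lies within the scatter), so this change from an aromatic to a non-aromatic ring is not separated from the scatter, and its true size stays unknown because the starting compound sits at a limit: the limit of > 4 mg/kg in this assay, at which 1 of the 4 values shown sits.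

The steps among compound 1, compound 2 and compound 3 still cannot be read. Open too is how cyclopentyl, between the two ring sizes shown, or plain phenyl without the nitrile would read at this place, and so whether cyclohexyl stands alone or belongs to a wider set of groups.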